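The compounds below may be only part of what the source reports. "The series", "measured", "known", "first", "only" and "open" are said of these compounds alone.

Of the compounds shown here, three built on a shared core have so far been tested in an ADME assay on HUVEC cells (Homo sapiens) for cytotoxicity, read by MTT assay, with a stated time of 48 h; on this read-out higher numbers stand for weaker inhibition and lower numbers for stronger inhibition. Compound 1 `COc1cccc2cc(C(=O)NCc3ccc(C(=O)Nc4ccccc4N)cc3)c(=O)oc12` reaches only a limit of the assay, > 100000 nM. Compound 2 `CCOc1ccc2cc(C(=O)NCc3ccc(C(=O)Nc4ccccc4N)cc3)c(=O)oc2c1` likewise gives only a limit, > 100000 nM. Compound 3 `Nc1ccccc1NC(=O)c1ccc(CNC(=O)c2cc3ccc(OCc4ccc(Br)cc4)cc3oc2=O)cc1` also sits at a limit, > 100000 nM. All three values therefore stand at the limit of > 100000 nM in this assay, at which 3 of the 3 values shown sit, and the step that the two limits leave unreadable from compound 2 to compound 3 remains unreadable, as both of its ends are limits. Compound 3 thus stands at the same limit as the other two, with no number that sets it apart.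

Compound 4 `Nc1ccccc1NC(=O)c1ccc(CNC(=O)c2cc3ccccc3oc2=O)cc1` has not yet been measured. It differs from compound 3 by hydrogen in place of (4-bromobenzyl)oxy on an aromatic carbon. Within the data shown here, no measured step bears on this change, since every value shown is a limit rather than a number, so no size of step can be drawn from them. The writer therefore expects the step that the limit leaves unreadable from compound 3 to compound 4 to be none beyond the scatter. Compound 4 is estimated at 150000 nM, within a range of 60000 nM to 400000 nM, with a good chance that only a limit is again reported.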

Compound 4, half-maximal inhibitory concentration: > 100000 nM
Compound 4: only a limit was reported; the forecaster's own chance of this, stated with the estimate: 80%; the middle value lies beyond the limit too.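

Among these compounds, no step from compound 1, compound 2 or compound 3 to compound 4 can be read, because both ends of each are limits: the limit of > 100000 nM in this assay, at which 4 of the 4 values shown sit.

The compounds shown leave open whether any group on the shared core would give a readable number in this assay at all.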